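Phenylsulfonyl for 3-chlorobenzyl, repeated on a second core

The source may report more compounds than this note shows. Statements on the series, on what has been measured and on what is new or still open speak of the compounds shown alone.

Two pairs share one change. Compound 1 `C#CCNC1CCc2c(OCCCCN3CCN(c4cccc5c4ccn5Cc4cccc(Cl)c4)CC3)cccc21` carries a 3-chlorobenzyl group on the aromatic nitrogen and in an assay on BTI cells for inhibition of Amine oxidase [flavin-containing] B (Homo sapiens), read by fluorescence, with stated times of 30 min and 1 h, tested at 1 uM (a higher number here means more inhibition at the concentration tested (going by the name of the read-out), a lower number less inhibition), compound 1 gives 100%. Compound 2 `C#CCNC1CCc2c(OCCCCN3CCN(c4cccc5c4ccn5S(=O)(=O)c4ccccc4)CC3)cccc21` differs from it by phenylsulfonyl in place of 3-chlorobenzyl on an aromatic nitrogen and in this assay compound 2 gives 44%. The measured step is a number 56 percentage points lower from compound 1 to compound 2 (beyond the scatter).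

Compound 3 `C[C@H](NCc1ccc(OCCCCCN2CCN(c3cccc4c3ccn4Cc3cccc(Cl)c3)CC2)cc1)C(N)=O` stands on a different core; how its core differs from that of compound 1 is not broken down here. In this assay compound 3 gives 43%, a number within the scatter of that of compound 2, so no order between compound 2 and compound 3 is claimed.

Compound 4 `C[C@H](NCc1ccc(OCCCCCN2CCN(c3cccc4c3ccn4S(=O)(=O)c3ccccc3)CC2)cc1)C(N)=O` is the not yet measured partner of compound 3, differing by phenylsulfonyl in place of 3-chlorobenzyl on an aromatic nitrogen. The place is the same word for word as in the first pair, so this is the same change.

Because the measured step of a number 56 percentage points lower from compound 1 to compound 2 (beyond the scatter) was large and compound 3 starts from 43%, a step of about a number 33 percentage points lower from compound 3 to compound 4 (beyond the scatter) is expected from compound 3 to compound 4, bounded below by zero inhibition. Compound 4 is estimated to give 10%, expected between 0% and 35%.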

Compound 4, a percentage reported as inhibition, at one concentration (the size of the read-out at that concentration, not a potency): 17%
Beside the measured number, compound 4's estimate is 7 percentage points below it; the range from low to high includes it.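

In this assay, phenylsulfonyl in place of 3-chlorobenzyl on an aromatic nitrogen again lowers inhibition on the second core, with a number 26 percentage points lower from compound 3 to compound 4 (beyond the scatter), so the direction of the change carries over from the core of compound 1. The size does not carry over, and the two steps differ: the same change on two cores in this assay, a number 56 percentage points lower (beyond the scatter) from compound 1 to compound 2 and a number 26 percentage points lower (beyond the scatter) from compound 3 to compound 4, 30 percentage points apart, beyond the scatter of two such steps These two cores give no rule for a third core, the readings are sizes at one concentration rather than potencies, and with compound 1 at 100%, the top of the percentage scale, the full size of its step cannot be read.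

On these data alone, it remains open whether the loss follows from the sulfonyl link, from the absence of the chlorine or from both, and an unsubstituted benzyl or a benzoyl group on that nitrogen would separate these. As far as these compounds go, it is also open which part of the difference between the two cores sets the size of the step, whether the amine end or the length of the chain.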